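The source may report more compounds than this note shows. Statements on the series, on what has been measured and on what is new or still open speak of the compounds shown alone.

Measured so far in a functional assay on SW-620 cells (Homo sapiens) for inhibition, read by MTT assay, with a stated time of 72 h (a lower number here means a stronger inhibitor, a higher number a weaker inhibitor), are:
- compound 1 `COc1cc(NC(C)CCCNC(=O)NNC(=O)Nc2ccc(C(F)(F)F)cc2)c2ncccc2c1` with 12000 nM
- compound 2 `COc1cc(NC(C)CCCNC(=O)NNC(=O)Nc2ccc(Br)cc2)c2ncccc2c1` with 17000 nM
- compound 3 `COc1cc(NC(C)CCCNC(=O)Nc2cccc(C(F)(F)F)c2)c2ncccc2c1` with 22000 nM

Compound 3 at 22000 nM stands within the scatter of compound 1 and of compound 2, so the three values show no order. The change to compound 4 `COc1cc(NC(C)CCCNC(=O)NNC(=O)Nc2ccc(O)cc2)c2ncccc2c1` is ((4-hydroxyphenyl)carbamoyl)amino in place of 3-(trifluoromethyl)phenyl on an amide-type nitrogen and amounts to ((4-hydroxyphenyl)carbamoyl)amino in place of 3-(trifluoromethyl)phenyl on an amide-type nitrogen. Among the measured compounds shown here, two measured steps bear on it: a 1.3-fold higher number from compound 2 to compound 3 (0.11 log units; within the scatter) for a swap of the reverse kind at that nitrogen and a 1.4-fold higher number from compound 1 to compound 2 (0.15 log units; within the scatter) for a change on an aromatic carbon. For the measured compounds named here, no measured compound carries the 4-hydroxyphenyl group. In this assay no step beyond the scatter is expected and a 1.6-fold lower number from compound 3 to compound 4 (0.20 log units; within the scatter) is the estimated size. Compound 4 is estimated at 14000 nM with an expected range of 5000 nM to 35000 nM here.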

Compound 4, half-maximal inhibitory concentration: > 100000 nM
Compound 4: only a limit was reported (the forecaster's own chance of this, stated with the estimate: 15%); middle value at least 7.1-fold (0.85 log units) from the limit.
By their numbers in this assay, from the lowest: compounds 1, 2 and 3 (each within the scatter of the next). At a limit, above all of these: compound 4.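

In this assay compound 4 is reported only as a limit: the limit of > 100000 nM in this assay, at which 1 of the 4 values shown sits. On the aromatic carbon, hydroxy in place of bromo gives an at least 5.8-fold higher number from compound 2 to compound 4 (0.76 log units; beyond the scatter), and hydroxy in place of trifluoromethyl gives an at least 8.3-fold higher number from compound 1 to compound 4 (0.92 log units; beyond the scatter), whereas bromo in place of trifluoromethyl gave only a 1.4-fold higher number from compound 1 to compound 2 (0.15 log units; within the scatter). Among the compounds shown here, at the amide-type nitrogen, the swap to ((4-hydroxyphenyl)carbamoyl)amino gives an at least 4.5-fold higher number from compound 3 to compound 4 (0.65 log units; beyond the scatter), so hydroxy is the first change to move the number beyond the scatter.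

As far as these compounds go, the true size of these steps stays open at the limit. Also open, from the compounds shown here alone, is whether a methoxy, an amine or a carboxylic acid on that aromatic carbon would behave like hydroxy or like bromo.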